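This account rests on a few compounds, and the source may have more. Where it says the series, first, only, none or still open, it means among the compounds named here.

Working notes on the series.

Compound 1 `COc1cc(CNCc2ccncc2)ccc1OCc1cnc(Cl)c(Cl)c1` gives 220 nM in a functional assay on HeLa cells (Homo sapiens) for inhibition, with a stated time of 72 h; on this read-out higher numbers stand for an effect only at larger amounts of compound and lower numbers for an effect already at smaller amounts. Compound 2 `COc1cc(CNCCNc2ccnc3cc(Cl)ccc23)ccc1OCc1ccc(Cl)nc1` gives 2700 nM in this assay, a step beyond the usual scatter. For compound 3 `COc1cc(CNC2CCCCC2)ccc1OCc1ccc(Cl)nc1` the entry in this assay reads "nd(insoluble)" (no result reported), so no number is recorded. Among the two values present, compound 1 stands at the lower end, with compound 2 as the only other measured entry.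

Compound 4 `COc1cc(CNCc2ccncc2)ccc1OCc1ccc(Cl)c(Cl)c1` has not yet been measured in this assay. It differs from compound 1 in one place: 3,4-dichlorophenyl in place of 5,6-dichloropyridin-3-yl on a saturated chain carbon bound to an oxygen on an aromatic ring. Among the compounds with values here, no step between two measured compounds corresponds to that change, so there is nothing in the present numbers to show whether it moves the value up or down. The expectation is therefore that compound 4 stays close to compound 1, with the step of a 1.4-fold higher number from compound 1 to compound 4 (0.13 log units; within the scatter) expected to remain within the scatter, in either direction. Compound 4 is estimated at 300 nM in this assay, with a range from 100 nM to 1000 nM.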

Compound 4, half-maximal effective concentration: 4000 nM
Compound 4: the middle estimate sits 13-fold (1.12 log units) below what was measured; measured number above the stated range.
By their numbers in this assay, from the lowest: compound 1; then compounds 2 and 4 (each within the scatter of the next).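

In this assay, within the data shown here, the exchange of 5,6-dichloropyridin-3-yl for 3,4-dichlorophenyl on a saturated chain carbon bound to an oxygen on an aromatic ring gives an 18-fold higher number from compound 1 to compound 4 (1.26 log units; beyond the scatter) and so shows that the value is sensitive to the ring at this position, which the earlier compounds could not show. The two groups have the same heavy-atom count and both carry two chlorines, but the entering ring has carbon in place of the ring nitrogen and lacks the hydrogen-bond acceptor counted for the leaving group. No measurement shown here gives a reason for this step.

On these data alone, it remains open how an unsubstituted pyridin-3-yl or a pyrimidin-5-yl group would read at this position. Also open, as far as these compounds go, is whether the step keeps its size when a morpholine replaces the amine part of compound 1.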